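This account rests on a few compounds, and the source may have more. Where it says the series, first, only, none or still open, it means among the compounds named here.

Of the compounds shown here, three have been measured in an ADME assay on Vero cells (Chlorocebus sabaeus) for cytotoxicity, read by sulforhodamine B assay, with a stated time of 72 h; a higher number here means a weaker inhibitor, a lower number a stronger inhibitor. Compound 1 `OC1CN(Cc2ccccc2)Cc2ccc(OCc3ccccc3)cc21` gives 31800 nM in this assay. Compound 2 `OC1CN(Cc2ccccc2)Cc2ccc(OCc3ccc(-c4ccccc4)cc3)cc21` gives 14800 nM. Compound 3 `OC1CCCc2ccc(OCc3ccccc3)cc21` gives 39000 nM, the highest of the three numbers; its value and that of compound 1 lie within the scatter of each other, while compound 2 gives a lower number than compound 3.

Compound 2 differs from compound 1 by phenyl in place of hydrogen on an aromatic carbon. The step this made is a 2.1-fold lower number from compound 1 to compound 2 (0.33 log units; beyond the scatter). Compound 3 is built on a different core from compound 1; the difference between the two cores is not broken down here.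

Compound 4 `OC1CCCc2ccc(OCc3ccc(-c4ccccc4)cc3)cc21` has not yet been measured in this assay. It differs from compound 3 by phenyl in place of hydrogen on an aromatic carbon. This is the same change, made in the same place, as the one that turns compound 1 into compound 2, so that the change occurs twice among the compounds shown. Going by the values given here, since the single known example of this change, in compound 1 against compound 2, gave a modest step beyond the scatter, a step of similar size is expected from compound 3 to compound 4, namely a 2.1-fold lower number from compound 3 to compound 4 (0.31 log units; beyond the scatter); this expectation rests on the step of a 2.1-fold lower number from compound 1 to compound 2 (0.33 log units; beyond the scatter). Among the compounds with values here, with only one prior example, the uncertainty is wide. For compound 4 in this assay the estimate is 19000 nM, with a range from 9000 nM to 40000 nM considered likely.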

Compound 4, half-maximal inhibitory concentration: > 100000 nM
Compound 4: a limit, no number (the forecaster's own chance of this, stated with the estimate: 10%); middle value at least 5.2-fold (0.72 log units) from the limit.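

In this assay compound 4 gives > 100000 nM, which is a limit of the assay and not a number. Phenyl in place of hydrogen on an aromatic carbon gave an at least 2.5-fold higher number from compound 3 to compound 4 (0.40 log units; beyond the scatter), so the step seen on the core of compound 1 did not carry over to the core of compound 3, and the two steps run in opposite directions: the same change on two cores in this assay, a 2.1-fold lower number (0.33 log units; beyond the scatter) from compound 1 to compound 2 and an at least 2.5-fold higher number (0.40 log units; beyond the scatter) from compound 3 to compound 4, at least 5.5-fold (0.74 log units) apart, beyond the scatter of two such steps. Going by these compounds alone, this does not show how large the step on the core of compound 3 really is, why the two cores part, or how general the reversal is, with only one pair on each core and one of the two steps ending at a limit: the limit of > 100000 nM in this assay, at which 1 of the 4 values shown sits.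

The compounds shown leave open whether a smaller group in the same place, such as methyl or chloro, would also move the number in opposite directions on the two cores. They also leave open whether an amine or a carboxylic acid on the added phenyl would change the outcome on either core.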